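Ring Size at the Chain Terminus Across Two Cores

This account rests on a few compounds, and the source may have more. Where it says the series, first, only, none or still open, it means among the compounds named here.

The measured compounds and their values in a functional assay on MKN-45 cells (Homo sapiens) for cytotoxicity, read by MTT assay, with a stated time of 72 h; on this read-out higher numbers stand for weaker inhibition and lower numbers for stronger inhibition:
Compound 1 `COc1cc2c(Oc3ccc(NC(=O)c4cc(-c5ccc(C(F)(F)F)cc5)ccn4)cc3F)ccnc2cc1OCCCN1CCCCC1` gives 870 nM.
Compound 2 `COc1cc2c(Oc3ccc(NC(=O)c4cc(-c5ccc(C(F)(F)F)cc5)ccn4)cc3F)ccnc2cc1OCCCN1CCCC1` gives 260 nM.
Compound 3 `COc1cc2c(Oc3ccc(NC(=O)c4nccc(-c5ccccc5)n4)cc3F)ccnc2cc1OCCCN1CCCCC1` gives 1030 nM.

Compounds 1 and 2 share one core and differ in a single place: pyrrolidin-1-yl in place of piperidin-1-yl on a saturated chain carbon, three bonds along the chain from an oxygen on an aromatic ring. On this change the number moves a 3.3-fold lower number from compound 1 to compound 2 (0.52 log units; beyond the scatter), a step that lies beyond the scatter of this kind of measurement.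

Compound 3 carries a different core. The difference between the core of compound 1 and the core of compound 3 is not broken down here. In this assay compound 3 stands with the highest of the three numbers; its value and that of compound 1 lie within the scatter of each other, so no order between those two can be read, while compound 2 sits beyond the scatter below it.

Compound 4 `COc1cc2c(Oc3ccc(NC(=O)c4nccc(-c5ccccc5)n4)cc3F)ccnc2cc1OCCCN1CCCC1` is not yet measured. It stands to compound 3 as compound 2 stands to compound 1: pyrrolidin-1-yl in place of piperidin-1-yl on a saturated chain carbon, three bonds along the chain from an oxygen on an aromatic ring. The place of the change is described in the same words for both pairs, so this is the same change made on a second core.

Among the measured compounds shown here, the expectation for compound 4 rests on the single measured instance of this change, the step of a 3.3-fold lower number from compound 1 to compound 2 (0.52 log units; beyond the scatter), applied to the value of compound 3, 1030 nM. Whether a second core carries the step unchanged is not known from these three compounds, so the expected range is kept wide. The estimated step in this assay is a 3.2-fold lower number from compound 3 to compound 4 (0.51 log units; beyond the scatter). Compound 4 is therefore expected to give about 320 nM, with a likely span from 150 nM to 750 nM.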

Compound 4, half-maximal inhibitory concentration: 1360 nM
Beside the measured number, compound 4's estimate is 4.3-fold (0.63 log units) below it; measured number outside the range, above it.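

In this assay, putting pyrrolidin-1-yl in place of piperidin-1-yl on the second core gives a 1.3-fold higher number from compound 3 to compound 4 (0.12 log units; within the scatter), so the two ring sizes at the chain terminus cannot be told apart on this core. The change therefore does not carry from one core to the other as a fixed step, and the two measured instances differ by more than the scatter allows: the same change on two cores in this assay, a 3.3-fold lower number (0.52 log units; beyond the scatter) from compound 1 to compound 2 and a 1.3-fold higher number (0.12 log units; within the scatter) from compound 3 to compound 4, 4.4-fold (0.65 log units) apart, beyond the scatter of two such steps. This shows that the result on the core of compound 1 cannot simply be transferred to another core in this series, but it does not show which feature of the two cores accounts for the gap, and a single pair on each core cannot say how either step would hold up in further pairs.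

The compounds shown leave open whether a morpholine ring or an open-chain amine such as dimethylamino in place of these rings, or a longer chain in place of the propyl chain, would also behave differently on the two cores. They also leave open which part of the difference between the cores matters, something that a core carrying only part of that difference could help to settle.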